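The source may report more compounds than this note shows. Statements on the series, on what has been measured and on what is new or still open speak of the compounds shown alone.

Measured compounds in a functional assay on K562 cells (Homo sapiens) for antiproliferative activity, read by MTT assay; a higher number here means a weaker inhibitor, a lower number a stronger inhibitor:
compound 1, `COC(=O)N1CCCc2cc(S(=O)(=O)N3CC(c4ccccc4)NC3=O)ccc21`, gives > 20000 nM, which is a limit of the assay, not a number.
compound 2, `CCOC(=O)N1CCCc2cc(S(=O)(=O)N3CC(c4ccccc4)NC3=O)ccc21`, gives > 20000 nM, again a limit of the assay.
compound 3, `C=CCOC(=O)N1CCCc2cc(S(=O)(=O)N3CC(c4ccccc4)NC3=O)ccc21`, gives 473 nM.

Compound 1 therefore stands at the assay limit with no measured number, as the limit of > 20000 nM in this assay, at which 2 of the 3 values shown sit, shows. Compound 4, `O=C(CCl)N1CCCc2cc(S(=O)(=O)N3CC(c4ccccc4)NC3=O)ccc21`, differs from compound 1 by chloromethyl in place of methoxy on a carbonyl carbon. The three measured steps all change the same region of the shared core: a step that the two limits leave unreadable from compound 1 to compound 2, an at least 42-fold lower number from compound 1 to compound 3 (1.62 log units; beyond the scatter) and an at least 42-fold lower number from compound 2 to compound 3 (1.62 log units; beyond the scatter). None of them removes the methoxy itself, so they bear on the new step only indirectly: they show that a small change there can leave the value at the limit or lower it by a large amount. For compound 4 the expected step is an at least 5.0-fold lower number from compound 1 to compound 4 (0.69 log units; beyond the scatter), with a real chance that the assay again reports only a limit. Compound 4 is estimated at 4000 nM, expected to fall between 500 nM and 20000 nM.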

Compound 4, half-maximal inhibitory concentration: 1100 nM
Compound 4: middle estimate off by 3.6-fold (0.56 log units), on the high side, within the range that was stated.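

In this assay, replacing methoxy with chloromethyl on the carbonyl carbon gives an at least 18-fold lower number from compound 1 to compound 4 (1.25 log units; beyond the scatter), and replacing ethoxy with chloromethyl gives an at least 18-fold lower number from compound 2 to compound 4 (1.25 log units; beyond the scatter). Among the earlier compounds, only the allyloxy group of compound 3 gave a measured value, so compound 4 shows that a group with no oxygen on the carbonyl carbon can also give one. Chloromethyl does not match allyloxy, however, with a 2.3-fold higher number from compound 3 to compound 4 (0.37 log units; beyond the scatter).

On these data alone, how a plain methyl or a bromomethyl on this carbonyl carbon would compare stays open, so the part played by the chlorine cannot be told. Compound 1 and compound 2 give only limits, so the true sizes of their steps to compound 4 also stay unknown: the limit of > 20000 nM in this assay, at which 2 of the 4 values shown sit.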